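A few compounds are considered here, and "the series" means these few. Any claim that something is new, unique, unknown or untested is made for them only; others in the source may bear on it.

Measured so far:
compound 1, `COc1ccc(-c2cc(/C=C/C(=O)c3ccc(N)cc3)[nH]n2)cc1`, -60%;
compound 2, `COc1cc(-c2cc(/C=C/C(=O)c3ccc(Cl)c(Cl)c3)[nH]n2)cc(OC)c1OC`, -74%.

In a functional assay on HOP-62 cells (Homo sapiens) for cytotoxicity, read by sulforhodamine B assay, with a stated time of 48 h, tested at 100 uM (a lower number here means a stronger effect, a higher number a weaker effect of the compound at the concentration tested), compound 1 gives -60%, the highest of the two numbers; compound 2 gives -74%, a number lower by more than the scatter. Going by the values given here, the two compounds differ in several places, so no single step between them can be read. Compound 3, `COc1ccc(-c2cc(/C=C/C(=O)c3ccc(N)cc3)[nH]n2)cc1OC`, differs from compound 1 by methoxy in place of hydrogen on an aromatic carbon, on an aromatic carbon ortho to a methoxy group. Among the compounds with values here, with no comparable step measured, the expected change from compound 1 to compound 3 is a number 5 percentage points lower from compound 1 to compound 3 (within the scatter), a shift small enough to stay within the scatter. Compound 3 is therefore estimated at -65%, in the range from -85% to -40%.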

Compound 3, a percentage reported as activity, at one concentration (the size of the read-out at that concentration, not a potency): -98%
Compound 3: the middle estimate sits 33 percentage points above what was measured; measured number below the stated range.
By their numbers in this assay, from the lowest: compound 3; then compound 2; then compound 1.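

In this assay, methoxy in place of hydrogen on an aromatic carbon, ortho to a methoxy group and meta to a large group, brings a number 38 percentage points lower from compound 1 to compound 3 (beyond the scatter). This shows that the position is far from silent: adding only 2 heavy atoms here changes the read-out by a large step. Nothing available explains why this position responds so strongly.

On these data alone, whether a hydroxyl or an ethoxy at the same place would give a similar number remains open. So does whether the step would hold in compounds without the amine of compound 1.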